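The compounds below may be only part of what the source reports. "The series", "measured", "known", "first", "only" and "open" are said of these compounds alone.

Within the data shown here, in a functional assay on the whole organism for inhibition, with Mythimna separata as the target, with a stated time of 5 days (on this read-out lower numbers stand for an effect already at smaller amounts and higher numbers for an effect only at larger amounts of compound), compound 1 (`CCCCn1ncc(OCc2nnc(-c3ccc(F)cc3)o2)c(Cl)c1=O`) gives 161000 nM, the higher of the two numbers so far. Compound 2 (`CC(C)(C)n1ncc(OCc2nnc(-c3ccc(F)cc3)o2)c(Cl)c1=O`) gives 5200 nM. Compound 3 (`CCCCn1ncc(OCc2nnc(-c3ccc(Cl)cc3)o2)c(Cl)c1=O`) keeps the butyl group of compound 1 and carries 4-chlorophenyl in place of 4-fluorophenyl: chloro in place of fluoro on an aromatic carbon. Among the measured compounds shown here, the only measured step, a 31-fold lower number from compound 1 to compound 2 (1.49 log units; beyond the scatter), is large, but it concerns the group on an aromatic nitrogen, not the aromatic carbon changed here, so it bears only weakly on this change. For the measured compounds named here, no measured step covers chloro in place of fluoro. The data therefore support no direction, and no step beyond the scatter is expected in this assay, though the range stays wide. The expected step is a 1.3-fold lower number from compound 1 to compound 3 (0.13 log units; within the scatter). For compound 3 the estimated value is 120000 nM, with an expected range from 40000 nM to 350000 nM.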

Compound 3, half-maximal effective concentration: 223000 nM
Compound 3: the middle estimate sits 1.9-fold (0.27 log units) below what was measured; measured number inside the range.
By their numbers in this assay, from the lowest: compound 2; then compounds 1 and 3 (each within the scatter of the next).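

Read in this assay the exchange of 4-fluorophenyl for 4-chlorophenyl stays within the scatter (a 1.4-fold higher number from compound 1 to compound 3 (0.14 log units; within the scatter)), so with the butyl group on the aromatic nitrogen this position tolerates chloro in place of fluoro without a readable shift. Among these compounds, the exchange on the aromatic carbon thus stands apart from tert-butyl in place of butyl on the aromatic nitrogen, the only step so far beyond the scatter (a 31-fold lower number from compound 1 to compound 2 (1.49 log units; beyond the scatter)). No measurement at hand offers an explanation for this result.

Going by these compounds, whether chloro in place of fluoro also stays within the scatter with tert-butyl on the aromatic nitrogen remains open. Also open, on these data alone, are a methoxy group or a nitrile on the same aromatic carbon, and a longer chain on the aromatic nitrogen.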